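A few compounds are considered here, and "the series" means these few. Any claim that something is new, unique, unknown or untested is made for them only; others in the source may bear on it.

Measured in a functional assay on KG-1 cells (Homo sapiens) for antiproliferative activity, read by CCK-8 assay, with a stated time of 72 h; on this read-out lower numbers stand for stronger inhibition and higher numbers for weaker inhibition:
- Compound 1 `Cc1ccc(C(=O)Nc2cccc(C(F)(F)F)c2)cc1-c1ccc2c(-c3ccc(C(=O)N4CCN(C)CC4)cc3)n[nH]c2c1`: 300 nM
- Compound 2 `CCn1cc(-c2n[nH]c3cc(-c4cc(C(=O)Nc5cccc(C(F)(F)F)c5)ccc4C)ccc23)cn1`: 257 nM
- Compound 3 `Cc1ccc(C(=O)Nc2cccc(C(F)(F)F)c2)cc1-c1ccc2c(-c3cnn(C4CC4)c3)n[nH]c2c1`: 108 nM

In this assay, compound 2 at 257 nM lies within the scatter of compound 1, and only compound 3 stands clearly apart from it. Compound 4 `Cc1ccc(C(=O)Nc2cccc(C(F)(F)F)c2)cc1-c1ccc2c(-c3cnn(CC(=O)N(C)C)c3)n[nH]c2c1` keeps the rest of compound 2 and alters one group: dimethylcarbamoyl in place of methyl on a saturated chain carbon bound to an aromatic nitrogen. Ethyl thus becomes (dimethylcarbamoyl)methyl on the aromatic nitrogen.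

Going by the values given here, only one measured step bears on this place: a 2.4-fold lower number from compound 2 to compound 3 (0.38 log units; beyond the scatter), with cyclopropyl in place of ethyl on an aromatic nitrogen. Among the compounds with values here, it is modest, but it is a much smaller exchange, and no measured compound carries dimethylcarbamoyl here. What the data do show is that compound 1 at 300 nM and compound 3 at 108 nM both remain in the same range. No step beyond the scatter is therefore expected, in either direction, though the uncertainty is wide. The expected step is a 1.2-fold lower number from compound 2 to compound 4 (0.07 log units; within the scatter). Compound 4 is estimated at 220 nM, with an expected range of 80 nM to 600 nM.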

Compound 4, half-maximal inhibitory concentration: 441 nM
The estimate for compound 4 lay 2.0-fold (0.30 log units) below the measured number, within the range that was stated.
By their numbers in this assay, from the lowest: compound 3; then compounds 2, 1 and 4 (each within the scatter of the next).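

In this assay, a 1.7-fold higher number from compound 2 to compound 4 (0.23 log units; within the scatter) shows that this position accepts dimethylcarbamoyl, with five heavy atoms and a hydrogen-bond acceptor, in place of methyl without a change beyond the scatter. Going by these compounds alone, the exchange on the aromatic nitrogen is nevertheless not neutral in every comparison: a 4.1-fold higher number from compound 3 to compound 4 (0.61 log units; beyond the scatter) is a modest step beyond the scatter, and with the earlier step from ethyl, it leaves cyclopropyl as the one group here that stands apart from both others. Nothing available accounts for this difference between the groups on the aromatic nitrogen.

The compounds shown leave open whether an amine or a carboxylic acid at the end of the chain would stay in this range. They also leave open whether a longer chain, or a cyclobutyl ring on the aromatic nitrogen, would match cyclopropyl.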